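Swapping the Ester for an Amide on the Shared Core

The compounds below may be only part of what the source reports. "The series", "measured", "known", "first", "only" and "open" are said of these compounds alone.

The shared core is that of compound 1 `COC(=O)C1=C(C)NC(=O)NC1c1ccoc1`. Among the compounds with values here, in an assay on membranes from CHO cells for displacement of a labelled ligand from adenosine receptor A1 (Homo sapiens), read by scintillation counting, with a stated time of 60 min, tested at 1 uM (a higher number here means more inhibition at the concentration tested (going by the name of the read-out), a lower number less inhibition), compound 1 gives 8%, the second highest of the three numbers measured so far. Compound 2 `COC(=O)C1=C(C)NC(=O)NC1c1cccs1` gives 6%, which is a number 2 percentage points lower from compound 1 to compound 2 (within the scatter). Compound 3 `COC(=O)C1=C(C)N(C)C(=O)NC1c1ccoc1` gives 15%, which is a number 7 percentage points higher from compound 1 to compound 3 (within the scatter). Compound 4 `CC1=C(C(N)=O)C(c2ccoc2)NC(=O)N1` has not yet been measured; it differs from compound 1 by amino in place of methoxy on a carbonyl carbon. Within the data shown here, neither measured step touches the methoxycarbonyl group, so no step seen so far bears directly on this change, and the two measured steps were both small. The expected step is therefore no change at the digits printed from compound 1 to compound 4 (within the scatter), staying within the scatter. The estimate for compound 4 is 8%, with a range from -4% to 20%.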

Compound 4, a percentage reported as inhibition, at one concentration (the size of the read-out at that concentration, not a potency): 1%
Beside the measured number, compound 4's estimate is 7 percentage points above it; the measured number falls inside the stated range.
By their numbers in this assay, from the lowest: compounds 4, 2, 1 and 3 (each within the scatter of the next, the first and the last beyond it).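

In this assay, within the data shown here, the change from methoxycarbonyl to carbamoyl gives a number 7 percentage points lower from compound 1 to compound 4 (within the scatter) and is the first step here that touches this carbonyl carbon. On this single step, putting amino in place of methoxy does not shift the number beyond the usual scatter. No measurement here bears on the reason for this step.

On these data alone, whether a carboxylic acid, an ethyl ester or an N-methyl amide on this carbonyl carbon would move the number beyond the scatter stays open. So does the effect of carbamoyl alongside thiophen-2-yl.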